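This account rests on a few compounds, and the source may have more. Where it says the series, first, only, none or still open, it means among the compounds named here.

In a functional assay on A549 cells (Homo sapiens) for inhibition, read by CCK-8 assay, with a stated time of 48 h (on this read-out higher numbers stand for weaker inhibition and lower numbers for stronger inhibition), compound 3 (`COc1cc(-c2ccnc3cc(-c4cn(C)c5ccccc45)nn23)cc(OC)c1OC`) gives 1340 nM, the highest number of the three measured, while compound 1 (`COc1cc(-c2ccnc3cc(-c4c[nH]c5ccccc45)nn23)cc(OC)c1OC`) gives 29 nM and compound 2 (`COc1cc(-c2ccnc3cc(-c4ccc5cc[nH]c5c4)nn23)cc(OC)c1OC`) gives 170 nM. Compound 4 (`COc1cc(-c2ccnc3cc(-c4ccc5cnn(C)c5c4)nn23)cc(OC)c1OC`) carries 1-methyl-1H-indazol-6-yl in place of 1-methyl-1H-indol-3-yl on an aromatic carbon. Going by the values given here, no measured step covers the indazole itself. The closest guide is the change from 1H-indol-3-yl to 1H-indol-6-yl (a 5.9-fold higher number from compound 1 to compound 2 (0.77 log units; beyond the scatter)), which was modest and raised the number. The large methyl step (a 46-fold higher number from compound 1 to compound 3 (1.66 log units; beyond the scatter)) is already contained in compound 3, and compound 4 keeps a methyl. A modest step to a higher number is therefore expected in this assay (a 2.6-fold higher number from compound 3 to compound 4 (0.42 log units; beyond the scatter)). Compound 4 is estimated at 3500 nM (range 700 nM to 12000 nM).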

Compound 4, half-maximal inhibitory concentration: 233 nM
For compound 4 the middle estimate is 15-fold (1.18 log units) above the measured one, and the stated range ends above it.
By their numbers in this assay, from the lowest: compound 1; then compounds 2 and 4 (each within the scatter of the next); then compound 3.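

In this assay the change to 1-methyl-1H-indazol-6-yl gives a 5.8-fold lower number from compound 3 to compound 4 (0.76 log units; beyond the scatter) at this position, so a methyl on the attached group does not by itself bring the high number of compound 3. The 1H-indol-6-yl group stays within the scatter of the new group, with a 1.4-fold higher number from compound 2 to compound 4 (0.14 log units; within the scatter) as the step, while the 1H-indol-3-yl group keeps its lead, with an 8.0-fold higher number from compound 1 to compound 4 (0.90 log units; beyond the scatter) on record. No evidence at hand accounts for these differences. Still open, as far as these compounds go, is whether 1H-indazol-6-yl without the methyl, or an amine on the indazole, would approach compound 1.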